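Hydroxamate linker swap on the shared core

A few compounds are considered here, and "the series" means these few. Any claim that something is new, unique, unknown or untested is made for them only; others in the source may bear on it.

Measured in an assay on isolated protein for inhibition of protein deacetylase HDAC6 (Homo sapiens), read by fluorescence; a higher number here means a weaker inhibitor, a lower number a stronger inhibitor:
compound 1 `CC(C)Oc1ccc(C(C)(C)O)cc1-c1cn(C)c(=O)c2[nH]c(C(=O)NCCCCCCC(=O)NO)cc12`: 5.4 nM
compound 2 `Cc1cc(F)cc(C)c1Oc1ccc(C(C)(C)O)cc1-c1cn(C)c(=O)c2[nH]c(C(=O)NCCCCCCC(=O)NO)cc12`: 17.2 nM
compound 3 `Cn1cc(-c2cc(C(C)(C)O)ccc2OC2CC2)c2cc(C(=O)NCCCCCCC(=O)NO)[nH]c2c1=O`: 5.5 nM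

Compound 1 gives the lowest of the three numbers; compound 3 lies within the scatter of it (a 1.0-fold higher number from compound 1 to compound 3 (0.01 log units; within the scatter)), while compound 2 is the furthest away (a 3.2-fold higher number from compound 1 to compound 2 (0.50 log units; beyond the scatter)). Both of these steps alter only the group on the oxygen on the aromatic ring. Compound 4 `CC(C)Oc1ccc(C(C)(C)O)cc1-c1cn(C)c(=O)c2[nH]c(C(=O)NCc3ccc(C(=O)NO)cc3)cc12` keeps that part as in compound 1 and changes the hydroxamate side instead: 4-(hydroxycarbamoyl)phenyl in place of 5-(hydroxycarbamoyl)pentyl on a saturated chain carbon bound to an amide-type nitrogen. For the measured compounds named here, no measured step touches this part of the molecule, so the measured steps offer no direct guide; the only anchor is compound 1 with its 5.4 nM. The step expected is a 1.4-fold lower number from compound 1 to compound 4 (0.13 log units; within the scatter), not beyond the scatter. Compound 4 is therefore estimated at 4 nM, between 0.8 nM and 20 nM.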

Compound 4, half-maximal inhibitory concentration: 52 nM
Beside the measured number, compound 4's estimate is 13-fold (1.11 log units) below it, and the stated range ends below it.
By their numbers in this assay, from the lowest: compounds 1 and 3 (each within the scatter of the next); then compound 2; then compound 4.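

In this assay, the hydroxamate side proves sensitive: 4-(hydroxycarbamoyl)phenyl in place of 5-(hydroxycarbamoyl)pentyl gives a 9.6-fold higher number from compound 1 to compound 4 (0.98 log units; beyond the scatter), with the shared core and the isopropyl on oxygen unchanged. This exceeds the largest step seen for the group on the oxygen, a 3.2-fold higher number from compound 1 to compound 2 (0.50 log units; beyond the scatter), so this side matters more among the changes shown. No data at hand explain the size of this step.

Still open, going by these compounds, is whether a longer chain carrying the hydroxamate, or a cyclohexyl ring in place of the phenyl, would stay nearer compound 1. Also open, on these data alone, is whether the step keeps its size with cyclopropyl on the oxygen, as in compound 3.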